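The source may hold more compounds than are shown below. What is called first, only, known or untested is meant among the compounds shown, and "the series" means these compounds.

Among the measured compounds shown here, in a functional assay on A549 cells (Homo sapiens) for antiproliferative activity, read by MTT assay, with a stated time of 48 h (a lower number here means a stronger inhibitor, a higher number a weaker inhibitor), three compounds sharing one core have numbers so far. Compound 1 `Fc1ccc(-c2nn(-c3ccccc3)cc2-c2nc3ccccc3[nH]2)cc1` gives 1510 nM, compound 2 `Fc1ccc(-c2nn(-c3ccccc3)cc2-c2nc3cc(F)ccc3[nH]2)cc1` gives 1130 nM, and compound 3 `Fc1ccc(-c2nn(-c3ccccc3)cc2-c2nc3cc(Br)ccc3[nH]2)cc1` gives 5830 nM, the highest of the three. Compound 4 `Cc1ccc2[nH]c(-c3cn(-c4ccccc4)nc3-c3ccc(F)cc3)nc2c1` has not yet been measured. It carries methyl in place of bromo on an aromatic carbon.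

For the measured compounds named here, no measured step involves methyl directly, so the evidence is indirect. Bromo in place of hydrogen gave a 3.9-fold higher number from compound 1 to compound 3 (0.59 log units; beyond the scatter), and bromo in place of fluoro gave a 5.2-fold higher number from compound 2 to compound 3 (0.71 log units; beyond the scatter). Both steps are modest and beyond the scatter. Fluoro in place of hydrogen gave only a 1.3-fold lower number from compound 1 to compound 2 (0.13 log units; within the scatter), which lies within the scatter. Of the three substituents tried at this place, only the bromo of compound 3, at 5830 nM, stands apart, and methyl now removes it. A modest step to a lower number is therefore expected in this assay, estimated as a 2.3-fold lower number from compound 3 to compound 4 (0.37 log units; beyond the scatter). For compound 4 the expected value is 2500 nM, with an estimated range of 1000 nM to 6000 nM.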

Compound 4, half-maximal inhibitory concentration: 1440 nM
Compound 4: the middle estimate sits 1.7-fold (0.24 log units) above what was measured, and the stated range covers the measured number.
By their numbers in this assay, from the lowest: compounds 2, 4 and 1 (each within the scatter of the next); then compound 3.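

In this assay, a 4.0-fold lower number from compound 3 to compound 4 (0.61 log units; beyond the scatter) shows that the high number of compound 3 does not come with every single-heavy-atom group at this place, since methyl, also one heavy atom, does not share it. Methyl instead falls in with the other groups, with a 1.0-fold lower number from compound 1 to compound 4 (0.02 log units; within the scatter) and a 1.3-fold higher number from compound 2 to compound 4 (0.11 log units; within the scatter), so hydrogen, fluoro and methyl cannot be told apart here and bromo alone stands apart among the four compounds. Nothing measured here explains what sets bromo apart.

As far as these compounds go, it remains open whether chloro would read like bromo or like methyl, and how an amine or a carboxylic acid would fare at this place. From the compounds shown here alone, the substituted compounds all carry their group at this one place, so whether bromo has the same effect elsewhere on the shared core also remains open.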